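Adding One Carbon to a Brominated Catechol Chain

A few compounds are considered here, and "the series" means these few. Any claim that something is new, unique, unknown or untested is made for them only; others in the source may bear on it.

Of the compounds shown here, three from one series have been tested in a functional assay on DLD-1 cells (Homo sapiens) for cytotoxicity, read by MTT assay, with a stated time of 96 h; on this read-out lower numbers stand for stronger inhibition and higher numbers for weaker inhibition. Compound 1 `CCOCc1cc(O)c(O)c(Br)c1` gives 35100 nM. Compound 2 `CCCOCc1cc(O)c(O)c(Br)c1` gives 26300 nM in this assay. Compound 3 `CCOCc1cc(Br)c(O)c(O)c1Br` gives 7150 nM in this assay, the lowest of the three numbers, with its steps to both others beyond the scatter.

Compound 2 differs from compound 1 by methyl in place of hydrogen on a saturated chain carbon, two bonds along the chain from an oxygen on a saturated carbon. That step, a 1.3-fold lower number from compound 1 to compound 2 (0.13 log units; within the scatter), is too small to count as a real change. Compound 3 differs from compound 1 by bromo in place of hydrogen on an aromatic carbon; this step, a 4.9-fold lower number from compound 1 to compound 3 (0.69 log units; beyond the scatter), is a modest but real drop in the number, and it is also how the core of compound 3 differs from the core of compound 1.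

Compound 4 `CCCOCc1cc(Br)c(O)c(O)c1Br` has not yet been measured in this assay. Within the data shown here, it differs from compound 3 by methyl in place of hydrogen on a saturated chain carbon, two bonds along the chain from an oxygen on a saturated carbon, which is the same change, at the same place, as the one from compound 1 to compound 2. The expectation for compound 4 therefore rests on compound 1 and compound 2, whose step a 1.3-fold lower number from compound 1 to compound 2 (0.13 log units; within the scatter) stayed within the scatter, so the step from compound 3 to compound 4 is expected to be small as well, with the estimate being a 1.2-fold lower number from compound 3 to compound 4 (0.09 log units; within the scatter). Compound 4 is thus expected to give about 5800 nM in this assay, most likely between 2500 nM and 13000 nM.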

Compound 4, half-maximal inhibitory concentration: 1720 nM
Compound 4: middle estimate off by 3.4-fold (0.53 log units), on the high side; measured number below the stated range.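

In this assay, going from ethoxy to propoxy did not carry over unchanged from one core to the other: with the extra bromo on the core, the change gives a 4.2-fold lower number from compound 3 to compound 4 (0.62 log units; beyond the scatter), although without that bromo it stayed within the scatter, and the two steps differ: the same change on two cores in this assay, a 1.3-fold lower number (0.13 log units; within the scatter) from compound 1 to compound 2 and a 4.2-fold lower number (0.62 log units; beyond the scatter) from compound 3 to compound 4, 3.1-fold (0.49 log units) apart, beyond the scatter of two such steps

Seen from the other side, the added bromo gives a larger step with the propoxy chain, a 15-fold lower number from compound 2 to compound 4 (1.18 log units; beyond the scatter), than with the ethoxy chain: the same change on two cores in this assay, a 4.9-fold lower number (0.69 log units; beyond the scatter) from compound 1 to compound 3 and a 15-fold lower number (1.18 log units; beyond the scatter) from compound 2 to compound 4, 3.1-fold (0.49 log units) apart, beyond the scatter of two such steps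

These two comparisons rest on the same four compounds, so they are one finding seen from two sides: in this series the two changes do not act independently of each other on the number, but the data do not show why, and one set of four compounds cannot show whether the same holds on any other core.

From the compounds shown here alone, it remains open whether a longer chain, such as butoxy, would lower the number further on the core with the extra bromo or whether the trend would stop there. Also open, going by these compounds, is whether chloro in place of the bromo, or an amine in place of the chain oxygen, would show the same dependence of one change on the other.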